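Hydrazide Nucleosides at the Limit of an Adenosine Assay

This account rests on a few compounds, and the source may have more. Where it says the series, first, only, none or still open, it means among the compounds named here.

Going by the values given here, compound 1 `CCNC(=O)[C@H]1O[C@@H](n2cnc3c(NNC(=O)c4ccc(Cl)cc4)ncnc32)[C@H](O)[C@@H]1O` and compound 2 `CCNC(=O)[C@H]1O[C@@H](n2cnc3c(NNC(=O)c4ccc(C)o4)ncnc32)[C@H](O)[C@@H]1O` are the first pair measured in an assay on CHO cells for displacement of a labelled ligand from adenosine receptor A3 (Homo sapiens); a lower number here means a stronger inhibitor, a higher number a weaker inhibitor. In this assay compound 1 gives > 5000 nM, which is a limit of the assay, not a number. Compound 2 likewise gives > 5000 nM, also a limit. Among the compounds with values here, the single computed step, a step that the two limits leave unreadable from compound 1 to compound 2, is therefore unreadable. Compound 3 `CCNC(=O)[C@H]1O[C@@H](n2cnc3c(NNC(=O)c4ccco4)nc(Cl)nc32)[C@H](O)[C@@H]1O` gives > 5000 nM, again a limit. Every measured value thus sits at the limit of > 5000 nM in this assay, at which 3 of the 3 values shown sit, so compound 3 stands nowhere that can be ranked. Compound 4 `CCNC(=O)[C@H]1O[C@@H](n2cnc3c(NNC(=O)c4sccc4C)nc(Cl)nc32)[C@H](O)[C@@H]1O` differs from compound 3 by 3-methylthiophen-2-yl in place of furan-2-yl on a carbonyl carbon. Within the data shown here, no measured step bears on this change, so no step beyond the scatter is expected, a number no higher from compound 3 to compound 4 (the limit leaves the size open). Compound 4 is accordingly estimated at 5000 nM, between 1500 nM and 20000 nM, most probably again reported only as a limit.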

Compound 4, inhibition constant: > 5000 nM
Compound 4 was reported as a limit (the forecaster's own chance of this, stated with the estimate: 80%); the middle value lies on the limit itself.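

Compound 3 and compound 4 are both reported only as limits in this assay, so no step between them can be read: the limit of > 5000 nM in this assay, at which 4 of the 4 values shown sit.

The compounds shown leave open whether any of these hydrazides would give a measurable value.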